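A few compounds are considered here, and "the series" means these few. Any claim that something is new, unique, unknown or untested is made for them only; others in the source may bear on it.

Measured compounds:
- compound 1 `CNc1ccc(C(=O)N2CCCCc3ccccc32)c(Cl)c1` — 35 nM
- compound 2 `C=CCNc1ccc(C(=O)N2CCCCc3ccccc32)c(Cl)c1` — 5.9 nM
- compound 3 `O=C(c1ccc(N2CCCCC2)cc1Cl)N1CCCCc2ccccc21` — 120 nM

In an assay on HeLa cells for binding affinity to Vasopressin V2 receptor (Homo sapiens) (on this read-out lower numbers stand for stronger inhibition and higher numbers for weaker inhibition), compound 3 carries the highest number of the three, separated from compound 1 by a 3.4-fold higher number from compound 1 to compound 3 (0.54 log units; beyond the scatter) and from compound 2 by a 20-fold higher number from compound 2 to compound 3 (1.31 log units; beyond the scatter); both steps sit beyond the scatter, so compound 3 is the weakest of the measured set.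

Compound 4 `O=C(c1ccc(-n2cccn2)cc1Cl)N1CCCCc2ccccc21` is not yet measured. It differs from compound 3 in one place: 1H-pyrazol-1-yl in place of piperidin-1-yl on an aromatic carbon.

Within the data shown here, only two measured steps touch the same position. Replacing methylamino by piperidin-1-yl gave a 3.4-fold higher number from compound 1 to compound 3 (0.54 log units; beyond the scatter), and replacing allylamino by piperidin-1-yl gave a 20-fold higher number from compound 2 to compound 3 (1.31 log units; beyond the scatter). Both show that the groups without the six-membered non-aromatic ring at this carbon give lower numbers than piperidin-1-yl in this assay. Nothing measured contains a five-membered aromatic ring at that carbon, so the direction of the move to 1H-pyrazol-1-yl is not fixed by the series; a smaller ring with two hydrogen-bond acceptors is a different kind of substituent from the one leaving. The working expectation is a modest move downward, with wide uncertainty.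

Compound 4 is estimated at 50 nM, range 12 nM to 200 nM, which would mean an expected step of a 2.4-fold lower number from compound 3 to compound 4 (0.38 log units; beyond the scatter).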

Compound 4, half-maximal inhibitory concentration: 8.8 nM
Beside the measured number, compound 4's estimate is 5.7-fold (0.75 log units) above it; measured number outside the range, below it.
By their numbers in this assay, from the lowest: compounds 2 and 4 (each within the scatter of the next); then compound 1; then compound 3.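

In this assay, a ring on this aromatic carbon does not by itself raise the number: a 14-fold lower number from compound 3 to compound 4 (1.13 log units; beyond the scatter) shows that the high number seen with piperidin-1-yl does not extend to 1H-pyrazol-1-yl, a five-membered aromatic ring with 0 hydrogen-bond donors. Replacing methylamino with a ring can therefore go either way, since piperidin-1-yl gave a higher number, whereas 1H-pyrazol-1-yl gives a 4.0-fold lower number from compound 1 to compound 4 (0.60 log units; beyond the scatter). The step to allylamino is small, with a 1.5-fold higher number from compound 2 to compound 4 (0.17 log units; within the scatter), so 1H-pyrazol-1-yl and allylamino cannot be ordered at this carbon, although they share little beyond their place on the ring.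

No supporting data bear on why the two rings differ so widely. Among these compounds, the single swap changes ring size, aromaticity and the number of ring nitrogens together, so pyrrolidin-1-yl, pyrrol-1-yl and imidazol-1-yl would be needed to separate these features, and phenyl would show whether any ring nitrogen is required at this carbon.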